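Swapping the Carboxy of Compound 3 for Methylpiperazinylmethyl

The source may report more compounds than this note shows. Statements on the series, on what has been measured and on what is new or still open speak of the compounds shown alone.

Measured so far in a functional assay on SMMC-7721 cells (Homo sapiens) for antiproliferative activity, read by MTT assay, with a stated time of 48 h; a higher number here means a weaker inhibitor, a lower number a stronger inhibitor:
compound 1 `CC(=O)OC/C1=C/C[C@](C)(CCC=C(C)C)/C=C/[C@@H](OC(=O)C=C(C)C)[C@](C)(OC(C)=O)/C=C/C1=O` gives 4130 nM
compound 2 `COC/C1=C/C[C@](C)(CCC=C(C)C)/C=C/[C@@H](OC(=O)C=C(C)C)[C@](C)(OC)/C=C/C1=O` gives 9380 nM
compound 3 `CC(C)=CCC[C@]1(C)/C=C/[C@@H](OC(=O)C=C(C)C)[C@](C)(O)/C=C/C(=O)/C(C(=O)O)=C\C1` gives > 10000 nM (a limit of the assay, not a number)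

Compound 3 has no measured number, and its entry of > 10000 nM in this assay is only a limit. The series holds a single such case: the limit of > 10000 nM in this assay, at which 1 of the 3 values shown sits. Compound 1 gives 4130 nM as a true number, and compound 2 gives 9380 nM as another.

The next compound, compound 4 `CC(C)=CCC[C@]1(C)/C=C/[C@@H](OC(=O)C=C(C)C)[C@](C)(O)/C=C/C(=O)/C(CN2CCN(C)CC2)=C\C1`, has (4-methylpiperazin-1-yl)methyl in place of carboxy on a double-bonded ring carbon and keeps the rest of the core of compound 3. Among the measured compounds shown here, no measured pair of compounds shows what this exchange does, so any expectation rests on thin ground. The shared core does reach numbers in this assay, as compound 1 at 4130 nM and compound 2 at 9380 nM show, and a modest move towards a stronger inhibitor is therefore expected. The estimated step is an at least 2.0-fold lower number from compound 3 to compound 4 (0.30 log units; that floor lies within the scatter) in this assay and stays uncertain in size, given the limit it starts from. For compound 4 the estimated value is 5000 nM, with an expected range from 1500 nM to 16000 nM in the same assay.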

Compound 4, half-maximal inhibitory concentration: 2940 nM
For compound 4 the middle estimate is 1.7-fold (0.23 log units) above the measured one; measured number inside the range.
By their numbers in this assay, from the lowest: compounds 4 and 1 (each within the scatter of the next); then compound 2. At a limit, above all of these: compound 3.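

In this assay, the exchange of carboxy for (4-methylpiperazin-1-yl)methyl on a double-bonded ring carbon gives an at least 3.4-fold lower number from compound 3 to compound 4 (0.53 log units; beyond the scatter), the only measured step at this position among the compounds shown. Among the compounds shown here, the earlier compounds showed only that the shared core could reach a number with other substituents, whereas this step shows that the position accepts a group carrying a six-membered non-aromatic ring with 2 hetero atoms and that the exchange gives a lower number than the carboxy compound. The entry for compound 3 is a limit, so the step sets a floor and gives no exact size: the limit of > 10000 nM in this assay, at which 1 of the 4 values shown sits.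

The compounds shown leave open whether the lower number follows from the loss of carboxy, from the entry of (4-methylpiperazin-1-yl)methyl, or from both together. A hydroxymethyl group, an open-chain dimethylaminomethyl group or a piperidin-1-ylmethyl group on the same ring carbon would help to separate these readings, and would also test whether the second ring nitrogen of the piperazine matters here.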